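Swapping Iodine for a Thiophene Ring on the Core

This account rests on a few compounds, and the source may have more. Where it says the series, first, only, none or still open, it means among the compounds named here.

Compound 1 `Cc1ncnc2c1c(I)cn2[C@@H]1O[C@H](CO)[C@@H](O)[C@H]1O` is the reference. Among the compounds with values here, in a functional assay on HCT-116 cells (Homo sapiens), read by MTT assay, with a stated time of 72 h (a lower number here means a stronger inhibitor, a higher number a weaker inhibitor), compound 1 gives 7570 nM, the only measured number among the three compounds. Compound 3 `CNc1ncnc2c1c(I)cn2[C@@H]1O[C@H](CO)[C@@H](O)[C@H]1O` carries methylamino in place of methyl, and in this assay compound 3 reaches only the limit > 100000 nM. That step, an at least 13-fold higher number from compound 1 to compound 3 (1.12 log units; beyond the scatter), is a large loss, ending at the limit (the limit of > 100000 nM in this assay, at which 1 of the 3 values shown sits). Compound 2 `COc1ncnc2c1c(-c1ccccc1)cn2[C@@H]1O[C@H](CO)[C@@H](O)[C@H]1O` differs from compound 1 in two places, methoxy for methyl and phenyl for iodo, and in this assay compound 2 sits at the limit > 20000 nM, the limit (the limit of > 20000 nM in this assay, at which 1 of the 3 values shown sits).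

Compound 4 `Cc1ncnc2c1c(-c1ccsc1)cn2[C@@H]1O[C@H](CO)[C@@H](O)[C@H]1O` differs from compound 1 in one place: thiophen-3-yl in place of iodo on an aromatic carbon. Within the data shown here, no measured step covers this exact change; the step from compound 1 to compound 3 alters a different group and gives no guide. Among the measured compounds shown here, compound 2, the only compound with a ring at that place, sits at a limit, but its second change clouds the comparison. A weaker result is expected, with a moderate step of a 2.6-fold higher number from compound 1 to compound 4 (0.42 log units; beyond the scatter). Compound 4 is therefore estimated at 20000 nM, within 5000 nM to 80000 nM.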

Compound 4, half-maximal inhibitory concentration: 1430 nM
Estimate against measurement, compound 4: 14-fold (1.15 log units) above; the whole stated range lies above it.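

The place on the core that carries iodo in compound 1 tolerates a whole aromatic ring: in this assay, thiophen-3-yl gives a 5.3-fold lower number from compound 1 to compound 4 (0.72 log units; beyond the scatter), a modest gain that lies beyond the scatter. This is the only single change shown that lowers the number, whereas methylamino in place of methyl at another place on the core raises it, so iodo is not required at this place for activity in these cells. Nothing measured here explains the gain.

With methyl kept on the core, thiophen-3-yl is the only ring shown at this place, so it remains open whether furan-3-yl or pyridin-3-yl would give a similar result. On these data alone, it also remains open how an amine or a carboxylic acid on that ring, or a longer chain in its place, would shift the number.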